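Aryl sulfonamide substituent swaps and compound 4

This account rests on a few compounds, and the source may have more. Where it says the series, first, only, none or still open, it means among the compounds named here.

Compound 2 `O=C1/C(=C/c2ccccc2F)CN(S(=O)(=O)c2ccc(C(F)(F)F)cc2)C/C1=C\c1ccccc1F` sits second highest of the three numbers in a functional assay on SMMC-7721 cells (Homo sapiens) for cytotoxicity, read by MTT assay, with a stated time of 24 h (a lower number here means a stronger inhibitor, a higher number a weaker inhibitor), where compound 2 gives 5200 nM. Compound 1 `Cc1ccc(S(=O)(=O)N2C/C(=C\c3ccccc3F)C(=O)/C(=C/c3ccccc3F)C2)cc1` gives 4100 nM, and compound 3 `N#Cc1ccc(S(=O)(=O)N2C/C(=C\c3ccccc3F)C(=O)/C(=C/c3ccccc3F)C2)cc1` gives 14600 nM. Compound 4 `CC(=O)Nc1ccc(S(=O)(=O)N2C/C(=C\c3ccccc3F)C(=O)/C(=C/c3ccccc3F)C2)cc1` differs from compound 2 by acetamido in place of trifluoromethyl on an aromatic carbon. The steps at this position are a 1.3-fold higher number from compound 1 to compound 2 (0.10 log units; within the scatter), a 2.8-fold higher number from compound 2 to compound 3 (0.45 log units; beyond the scatter) and a 3.6-fold higher number from compound 1 to compound 3 (0.55 log units; beyond the scatter); two of the three swaps raised the number beyond the scatter. Among the measured compounds shown here, no measured step involves acetamido, so only a modest rise is expected, and the expected step for compound 4 is a 1.4-fold higher number from compound 2 to compound 4 (0.16 log units; within the scatter) in this assay. Compound 4 is therefore estimated at 7500 nM, with a range from 3000 nM to 19000 nM.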

Compound 4, half-maximal inhibitory concentration: 7500 nM
The estimate for compound 4 equals the measured number at the digits printed; the range from low to high includes it.
By their numbers in this assay, from the lowest: compounds 1, 2, 4 and 3 (each within the scatter of the next, the first and the last beyond it).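

In this assay, acetamido on this aromatic carbon brings a hydrogen-bond donor and acceptor that trifluoromethyl lacks, yet every new step stays within the scatter: against trifluoromethyl (a 1.4-fold higher number from compound 2 to compound 4 (0.16 log units; within the scatter)), against methyl (a 1.8-fold higher number from compound 1 to compound 4 (0.26 log units; within the scatter)) and against cyano (a 1.9-fold lower number from compound 3 to compound 4 (0.29 log units; within the scatter)). Compound 4 therefore separates from neither compound 1 nor compound 3, although those two lie beyond the scatter of each other. No evidence at hand explains these numbers.

As far as these compounds go, whether an amine, a carboxylic acid or a longer acyl chain at this position would keep the number in this range remains open.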